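The source may hold more compounds than are shown below. What is called first, only, known or untested is meant among the compounds shown, and "the series" means these compounds.

Values in a functional assay on MDA-MB-468 cells (Homo sapiens) for antiproliferative activity, read by MTT assay, with a stated time of 72 h; a lower number here means a stronger inhibitor, a higher number a weaker inhibitor:
- Compound 1 `COc1cc(-c2nccn2CC(C)C)cc(OC)c1OC`: > 100000 nM. This value is a limit of the assay and not a number.
- Compound 2 `CCCCCn1ccnc1-c1cc(OC)c(OC)c(OC)c1`: 57900 nM.
- Compound 3 `COc1cccc(-n2ccnc2-c2cc(OC)c(OC)c(OC)c2)c1`: 10400 nM.

Not yet measured: compound 4 `COc1cc(-c2nccn2-c2ccc(Br)cc2)cc(OC)c1OC`.

Compound 3 holds the lower of the two numeric values in the series, and compound 2 is its nearest neighbour, with a 5.6-fold lower number from compound 2 to compound 3 (0.75 log units; beyond the scatter). The step from the limit value is an at least 9.6-fold lower number from compound 1 to compound 3 (0.98 log units; beyond the scatter).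

The change now in question is 4-bromophenyl in place of 3-methoxyphenyl on an aromatic nitrogen. Both measured steps into compound 3 replace a saturated chain with 3-methoxyphenyl, while the step to compound 4 keeps a six-membered aromatic ring of carbon only on that nitrogen. For the measured compounds named here, no measured step exchanges one such ring for another, so those two steps give no direct size and no direction for this change. In this assay, no step beyond the scatter is the central expectation, although a modest move in either direction remains possible. The estimated step is a 1.3-fold lower number from compound 3 to compound 4 (0.11 log units; within the scatter). Compound 4 is expected at 8000 nM, with an estimated range of 1500 nM to 40000 nM.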

Compound 4, half-maximal inhibitory concentration: 2700 nM
Estimate against measurement, compound 4: 3.0-fold (0.47 log units) above; the range from low to high includes it.
By their numbers in this assay, from the lowest: compound 4; then compound 3; then compound 2. At a limit, above all of these: compound 1.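

In this assay, for the compounds shown here, the substituent on the aromatic nitrogen still matters once a six-membered aromatic ring of carbon only is in place, which the earlier compounds could not show, since each of their steps replaced a saturated chain: a 3.9-fold lower number from compound 3 to compound 4 (0.59 log units; beyond the scatter). Exchanging one such ring for another therefore moves the number beyond the scatter, and compound 4 sits below every other compound shown, with the step from the pentyl compound growing to a 21-fold lower number from compound 2 to compound 4 (1.33 log units; beyond the scatter), compared with a 5.6-fold lower number from compound 2 to compound 3 (0.75 log units; beyond the scatter) for 3-methoxyphenyl. Compound 1 is a limit of the assay and not a number, so an at least 37-fold lower number from compound 1 to compound 4 (1.56 log units; beyond the scatter) gives only a floor for the change from isobutyl: the limit of > 100000 nM in this assay, at which 1 of the 4 values shown sits.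

3-Methoxyphenyl and 4-bromophenyl differ both in the substituent and in where it sits on the ring, so the compounds shown cannot separate these two changes. Unsubstituted phenyl, 3-bromophenyl, 4-methoxyphenyl and 4-chlorophenyl would each be needed to divide the step, and a ring carrying an amine or a carboxylic acid at this position remains an open question.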